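Ring substituent swap on a thiosemicarbazone: toward a nitrophenyl

This account rests on a few compounds, and the source may have more. Where it says the series, first, only, none or still open, it means among the compounds named here.

Measured compounds in a functional assay on NCI-H460 cells (Homo sapiens) for cytotoxicity, read by sulforhodamine B assay; a lower number here means a stronger inhibitor of growth, a higher number a weaker inhibitor of growth:
compound 1 `CC1=CC[C@@H]([C@@](C)(O)CCCC(C)(C)NC(=S)N/N=C\c2ccc(C)cc2)CC1` gives 10100 nM
compound 2 `COc1ccc(/C=N\NC(=S)NC(C)(C)CCC[C@](C)(O)[C@@H]2CC=C(C)CC2)cc1` gives 5100 nM
compound 3 `CC1=CC[C@@H]([C@@](C)(O)CCCC(C)(C)NC(=S)N/N=C\c2ccc(N(C)C)cc2)CC1` gives 19600 nM

Compound 3 stands with the highest of the three numbers. Its nearest neighbour is compound 1: a 1.9-fold higher number from compound 1 to compound 3 (0.29 log units; within the scatter). Going by the values given here, its furthest is compound 2: a 3.8-fold higher number from compound 2 to compound 3 (0.58 log units; beyond the scatter), the only step among the three that goes beyond the scatter. The remaining step, a 2.0-fold lower number from compound 1 to compound 2 (0.30 log units; within the scatter), also stays within the scatter.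

Compound 4 `CC1=CC[C@@H]([C@@](C)(O)CCCC(C)(C)NC(=S)N/N=C\c2ccccc2[N+](=O)[O-])CC1` is not yet measured. It differs from compound 3 in one place: 2-nitrophenyl in place of 4-(dimethylamino)phenyl on a carbon with a double bond to nitrogen. None of the three measured steps changes the ring in this way; each swaps one group for another at the same place on the ring, and all three are small. They suggest that changes on this ring shift this assay only modestly, so a moderate step is expected, most likely downward from the highest number, but not beyond the spread already seen. The step from compound 3 to compound 4 is therefore estimated at a 2.0-fold lower number from compound 3 to compound 4 (0.29 log units; within the scatter). Compound 4 is expected to give about 10000 nM, within 3000 nM to 35000 nM.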

Compound 4, concentration for 50% growth inhibition: 20600 nM
Compound 4: the middle estimate sits 2.1-fold (0.31 log units) below what was measured; measured number inside the range.
By their numbers in this assay, from the lowest: compounds 2, 1, 3 and 4 (each within the scatter of the next, the first and the last beyond it).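

In this assay, going by these compounds alone, 2-nitrophenyl in place of 4-(dimethylamino)phenyl on a carbon with a double bond to nitrogen is the first change of both the group and its place on the ring, and it stays within the scatter (a 1.1-fold higher number from compound 3 to compound 4 (0.02 log units; within the scatter)). The same group also separates from the other two: a 4.0-fold higher number from compound 2 to compound 4 (0.61 log units; beyond the scatter), and a 2.0-fold higher number from compound 1 to compound 4 (0.31 log units; beyond the scatter), the latter a step beyond the scatter where the step from 4-methylphenyl to 4-(dimethylamino)phenyl stayed within it. No supporting measurement bears on why these groups compare as they do.

The compounds shown leave open whether this result belongs to the nitro group itself or to where it sits on the ring, a question that 4-nitrophenyl and 2-methoxyphenyl would help separate. Also open, on these data alone, is how an unsubstituted phenyl, or a ring carrying a carboxylic acid or a primary amine, would compare with compound 2.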